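The source may report more compounds than this note shows. Statements on the series, on what has been measured and on what is new or still open speak of the compounds shown alone.

Measured in a functional assay (Platelet, plasma) for inhibition, with Homo sapiens as the target; on this read-out higher numbers stand for weaker inhibition and lower numbers for stronger inhibition:
- compound 1 `CC(c1ccccc1)S(=O)(=O)NC(=O)C1CCN(c2nc3c(cc2C#N)C(=O)OC3)CC1`: 4160 nM
- compound 2 `N#Cc1cc2c(nc1N1CCC(C(=O)NS(=O)(=O)Cc3ccc(F)cc3F)CC1)COC2=O`: 5200 nM

Compound 2 stands level with compound 1 within the scatter. Compound 3 `N#Cc1cc2c(nc1N1CCC(C(=O)NS(=O)(=O)c3ccc(Cl)s3)CC1)COC2=O` carries 5-chlorothiophen-2-yl in place of 2,4-difluorobenzyl on a sulfonyl sulfur. Among the measured compounds shown here, the only measured step at that place is a 1.3-fold higher number from compound 1 to compound 2 (0.10 log units; within the scatter), so no step beyond the scatter is expected in this assay, although this rests on a single step. The expected value for compound 3 is 3000 nM, with an estimated range of 800 nM to 11000 nM. This estimate means an expected 1.7-fold lower number from compound 2 to compound 3 (0.24 log units; within the scatter).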

Compound 3, half-maximal inhibitory concentration: 4470 nM
Compound 3: middle estimate off by 1.5-fold (0.17 log units), on the low side, within the range that was stated.
By their numbers in this assay, from the lowest: compounds 1, 3 and 2 (each within the scatter of the next).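

On the sulfonyl sulfur, 5-chlorothiophen-2-yl brings a five-membered aromatic ring with 1 hetero atom and fewer heavy atoms, yet in this assay there is a 1.2-fold lower number from compound 2 to compound 3 (0.07 log units; within the scatter) and a 1.1-fold higher number from compound 1 to compound 3 (0.03 log units; within the scatter). Compound 1, compound 2 and compound 3 therefore stand level within the scatter, so this place has now tolerated a ring swap as well as the earlier benzyl-type change. Nothing on hand explains this level result.

On these data alone, whether a carboxylic acid, an amine or a longer alkyl chain on the sulfonyl sulfur would stay level remains open. Also open, as far as these compounds go, is whether any change at this place can move the number beyond the scatter.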